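From Cyclohexyl to Vinyl on the Sulfur Chain

This account rests on a few compounds, and the source may have more. Where it says the series, first, only, none or still open, it means among the compounds named here.

In a functional assay on BGC-823 cells (Homo sapiens) for inhibition, read by MTT assay, with a stated time of 72 h (a lower number here means a stronger inhibitor, a higher number a weaker inhibitor), compound 3 `Cc1cc(N2CC[C@@H](C)[C@@H](N(C)c3ncnc4[nH]ccc34)C2)n2nc(SCC3CCCCC3)nc2n1` gives 16300 nM, and compound 1 `Cc1cc(N2CC[C@@H](C)[C@@H](N(C)c3ncnc4[nH]ccc34)C2)n2nc(SCc3ccccc3)nc2n1` gives 14400 nM. These two values sit together, with a 1.1-fold higher number from compound 1 to compound 3 (0.05 log units; within the scatter). Compound 2 `Cc1cc(N2CC[C@@H](C)[C@@H](N(C)c3ncnc4[nH]ccc34)C2)n2nc(SCc3nc4ccccc4[nH]3)nc2n1` reaches only a limit of the assay, > 100000 nM. Compound 4 `C=CCSc1nc2nc(C)cc(N3CC[C@@H](C)[C@@H](N(C)c4ncnc5[nH]ccc45)C3)n2n1` differs from compound 3 on the side chain: vinyl in place of cyclohexyl on a saturated chain carbon bound to a sulfur. Cyclohexyl for phenyl changed little, with a 1.1-fold higher number from compound 1 to compound 3 (0.05 log units; within the scatter), whereas 1H-benzimidazol-2-yl for phenyl gave an at least 6.9-fold higher number from compound 1 to compound 2 (0.84 log units; beyond the scatter). Among the compounds with values here, no measured step removes the ring outright, so the precedent is indirect. With only the hydrocarbon swap as a guide, a small change is expected, a 1.2-fold higher number from compound 3 to compound 4 (0.09 log units; within the scatter), within the scatter. For compound 4, the estimated value in this assay is 20000 nM, with an expected range of 8000 nM to 50000 nM.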

Compound 4, half-maximal inhibitory concentration: 40900 nM
Compound 4: middle estimate off by 2.0-fold (0.31 log units), on the low side, and the stated range covers the measured number.
By their numbers in this assay, from the lowest: compounds 1 and 3 (each within the scatter of the next); then compound 4. At a limit, above all of these: compound 2.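

In this assay, vinyl on a saturated chain carbon bound to a sulfur gives a real loss against both rings, which themselves sit within the scatter: a 2.5-fold higher number from compound 3 to compound 4 (0.40 log units; beyond the scatter), and a 2.8-fold higher number from compound 1 to compound 4 (0.45 log units; beyond the scatter). Compound 4, the only compound shown with no ring on that carbon, still gives a lower number than the 1H-benzimidazol-2-yl compound, an at least 2.4-fold lower number from compound 2 to compound 4 (0.38 log units; beyond the scatter). That comparison is open-ended, as compound 2 stands only at a limit: the limit of > 100000 nM in this assay, at which 1 of the 4 values shown sits.

Vinyl differs from cyclohexyl in both losing the ring and carrying a double bond, and the compounds shown do not separate these two changes. As far as these compounds go, how an ethyl group, an amine or a carboxylic acid would read at this place also stays open.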